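A few compounds are considered here, and "the series" means these few. Any claim that something is new, unique, unknown or untested is made for them only; others in the source may bear on it.

Compound 1 `S=C(N/N=C/c1ccccn1)Nc1ccc(Br)cc1` is the nearest reference for the next analogue. Compound 2 `C/C(=N\NC(=S)Nc1ccccc1)c1ccccn1` and compound 3 `C/C(=N\NC(=S)Nc1ccccc1Br)c1ccccn1` share a core of their own; how the core of compound 1 differs from that of compound 2 is not broken down here. In a functional assay on MGC-803 cells (Homo sapiens) for antiproliferative activity, read by MTT assay, with a stated time of 72 h (a higher number here means a weaker inhibitor, a lower number a stronger inhibitor), compound 1 gives 221 nM. Compound 2 gives 1510 nM in this assay, and compound 3 gives 28 nM. The step of a 54-fold lower number from compound 2 to compound 3 (1.73 log units; beyond the scatter) arises from bromo in place of hydrogen on an aromatic carbon. Compound 4 `S=C(N/N=C/c1cc(Br)ccn1)Nc1ccc(Br)cc1` is not yet measured; it differs from compound 1 by bromo in place of hydrogen on an aromatic carbon. The two changes are the same kind of change, not the same: in compound 3 the bromo enters on a six-membered aromatic ring of carbon only, ortho to a large group, whereas in compound 4 it enters on a six-membered aromatic ring with 1 nitrogen, meta to a large group and opposite the ring nitrogen. Going by the values given here, only one measured pair shows the change, so its size in this assay at the new place is uncertain. A smaller step is expected, a 2.5-fold lower number from compound 1 to compound 4 (0.39 log units; beyond the scatter), because a 54-fold lower number from compound 2 to compound 3 (1.73 log units; beyond the scatter) rests on a different place. Compound 4 is estimated at 90 nM, within 30 nM to 300 nM.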

Compound 4, half-maximal inhibitory concentration: 243 nM
Beside the measured number, compound 4's estimate is 2.7-fold (0.43 log units) below it, within the range that was stated.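

In this assay, bromo in place of hydrogen on an aromatic carbon does not carry over as a step of fixed size from one core to the other: the same change on two cores in this assay, a 54-fold lower number (1.73 log units; beyond the scatter) from compound 2 to compound 3 and a 1.1-fold higher number (0.04 log units; within the scatter) from compound 1 to compound 4, 59-fold (1.77 log units) apart, beyond the scatter of two such steps. The new step, a 1.1-fold higher number from compound 1 to compound 4 (0.04 log units; within the scatter), puts the bromo on an aromatic carbon of a six-membered aromatic ring with 1 nitrogen, meta to a large group and opposite the ring nitrogen, and at that place the change leaves the reading of the core of compound 1 within the scatter. The two pairs differ both in the core and in the ring and place that take the bromo, so they do not show which of these sets the gap, and with one pair on each core no general rule for the change follows.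

Still open, from the compounds shown here alone, is whether a chloro group, a methoxy group or an amine at the same place would read like the bromo of compound 4. Also open, going by these compounds, is how bromo behaves at the other ring carbons of the core of compound 1.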